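The source may report more compounds than this note shows. Statements on the series, on what has been measured and on what is new or still open speak of the compounds shown alone.

Measured so far:
compound 1, `O=c1oc2c(O)c(O)ccc2cc1-c1ccc(O)cc1` — > 30000 nM
compound 2, `O=c1oc2c(O)cccc2cc1-c1ccc(O)c(O)c1` — > 30000 nM

Both compounds were tested in an assay on CHO cells for displacement of a labelled ligand from adenosine receptor A2b (Homo sapiens), read by radioligand binding; on this read-out lower numbers stand for stronger inhibition and higher numbers for weaker inhibition. Compound 1 gave > 30000 nM, which is a limit of the assay rather than a number. Compound 2 gave > 30000 nM, again a limit and not a number. Where compound 2 stands is therefore known only as a boundary: the limit of > 30000 nM in this assay, at which 2 of the 2 values shown sit.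

Compound 3, `O=c1oc2c(O)c(O)ccc2cc1-c1ccc(O)c(O)c1`, is the next compound and has not yet been tested in this assay. It differs from compound 2 in one place: hydroxy in place of hydrogen on an aromatic carbon. The change merges the hydroxy pattern of the fused rings seen in compound 1 with the hydroxy pattern of the pendant ring seen in compound 2.

For the measured compounds named here, no measured step stands between two compounds here, so the size of the expected change cannot be read from data. With compound 2 at a limit, the step from compound 2 to compound 3 is expected to be about a number no higher from compound 2 to compound 3 (the limit leaves the size open), which is not beyond the scatter. For compound 3 the estimate is 30000 nM, in a range from 5000 nM to 100000 nM, with a real chance that the assay again reports only a limit.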

Compound 3, inhibition constant: > 30000 nM
Compound 3: a limit, no number; the forecaster's own chance of this, stated with the estimate: 70%; the middle value lies on the limit itself.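

For the compounds shown here, compound 3 gives > 30000 nM in this assay and this is a limit, not a number, so no step from compound 1 or compound 2 to compound 3 can be read. How strong these three compounds really are stays open, and whether the added hydroxy changes anything, since only a boundary is known: the limit of > 30000 nM in this assay, at which 3 of the 3 values shown sit.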